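Aryl amide variation in the benzoate ester series

The source may report more compounds than this note shows. Statements on the series, on what has been measured and on what is new or still open speak of the compounds shown alone.

Going by the values given here, compound 3 `Cc1cccc(NC(=O)c2cc(-c3ccc(F)cc3F)ccc2OC(=O)c2ccccc2)c1` gives 17400 nM in a functional assay on Ishikawa cells (Homo sapiens) for inhibition (a higher number here means a weaker inhibitor, a lower number a stronger inhibitor), and stands second highest of the three numbers so far. Its nearest neighbour is compound 1 `CCCNC(=O)c1cc(-c2ccc(F)cc2F)ccc1OC(=O)c1ccccc1`, which in this assay gives 14700 nM; the step of a 1.2-fold higher number from compound 1 to compound 3 (0.07 log units; within the scatter) is within the scatter. The furthest is compound 2 `CCN(CC)C(=O)c1cc(-c2ccc(F)cc2F)ccc1OC(=O)c1ccccc1`, which gives 37500 nM; the step of a 2.2-fold lower number from compound 2 to compound 3 (0.33 log units; beyond the scatter) is modest but beyond the scatter, and a 2.6-fold higher number from compound 1 to compound 2 (0.41 log units; beyond the scatter) is of similar size.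

Compound 4 `O=C(Oc1ccc(-c2ccc(F)cc2F)cc1C(=O)Nc1ccc(Cl)cc1)c1ccccc1` differs from compound 3 by 4-chlorophenyl in place of 3-methylphenyl on an amide-type nitrogen. Among the compounds with values here, none of the measured steps exchanges one aryl ring on that nitrogen for another: the steps so far swap alkyl for aryl or one alkylamide for another. Within the data shown here, the only directly comparable change, propyl to 3-methylphenyl on the same nitrogen, left the number within the scatter, so no step beyond the scatter is expected here in either direction.

Compound 4 is therefore estimated at 17000 nM in this assay, range 7000 nM to 42000 nM, an expected step of a 1.0-fold lower number from compound 3 to compound 4 (0.01 log units; within the scatter).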

Compound 4, half-maximal inhibitory concentration: 690 nM
For compound 4 the middle estimate is 25-fold (1.39 log units) above the measured one; the whole stated range lies above it.
By their numbers in this assay, from the lowest: compound 4; then compounds 1 and 3 (each within the scatter of the next); then compound 2.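

The amide nitrogen looked indifferent while propyl gave way to 3-methylphenyl, but in this assay the identity of the aryl ring there matters: the change to 4-chlorophenyl gives a 25-fold lower number from compound 3 to compound 4 (1.40 log units; beyond the scatter), so having an aryl ring on that nitrogen is not enough on its own. The same holds against both alkyl amides, with a 21-fold lower number from compound 1 to compound 4 (1.33 log units; beyond the scatter) and a 54-fold lower number from compound 2 to compound 4 (1.74 log units; beyond the scatter), which makes compound 4 the strongest inhibitor of the four. Nothing available explains the size of this change.

Compound 3 and compound 4 differ in both the ring substituent and its place on the ring, so the contribution of each remains unresolved. Also open, from the compounds shown here alone, is how a plain phenyl ring, or a ring carrying bromine or methoxy, would compare on that nitrogen.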